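The source may report more compounds than this note shows. Statements on the series, on what has been measured and on what is new or still open speak of the compounds shown alone.

In a functional assay on HL-60 cells (Homo sapiens) for antiproliferative activity, with a stated time of 24 h (a higher number here means a weaker inhibitor, a lower number a stronger inhibitor), compound 1 `NC(=O)c1c(NC(=O)c2ccccc2Cl)sc2c1CCN(Cc1cc(Cl)cc(Cl)c1)C2` gives 15800 nM. For the measured compounds named here, compound 2 `NC(=O)c1c(NC(=O)c2cccc([N+](=O)[O-])c2)sc2c1CCN(Cc1ccc(Cl)cc1Cl)C2` gives 19800 nM in this assay, a value within the usual scatter of that of compound 1, so on the numbers so far compound 1 stands level with its only companion and neither can be called the better inhibitor. Compound 3 `COc1ccc(NC(=S)N2CCc3c(sc(NC(=O)c4ccccc4Cl)c3C(N)=O)C2)cc1` has not yet been measured; it differs from compound 1 in one place: a group of 11 heavy atoms (8 carbon, 1 nitrogen, 1 oxygen, 1 sulfur; one six-membered aromatic ring of carbon only) in place of a group of 9 heavy atoms (7 carbon, 2 chlorine; one six-membered aromatic ring of carbon only), on an amine nitrogen in a ring. Going by the values given here, no measured pair shows this change, so the step of a 1.1-fold lower number from compound 1 to compound 3 (0.02 log units; within the scatter) is expected to be small, with no gain or loss beyond the scatter. Compound 3 is therefore estimated at 15000 nM, within 5000 nM to 50000 nM.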

Compound 3, half-maximal inhibitory concentration: 15700 nM
The estimate for compound 3 lay 1.0-fold (0.02 log units) below the measured number; the measured number falls inside the stated range.
By their numbers in this assay, from the lowest: compounds 3, 1 and 2 (each within the scatter of the next).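

In this assay, the first pair differing in one place gives a 1.0-fold lower number from compound 1 to compound 3 (0.00 log units; within the scatter). On the amine nitrogen in a ring, 3,5-dichlorobenzyl and a group containing nitrogen, oxygen and sulfur therefore cannot be told apart, although the two groups differ in their atoms. Nothing at hand explains this result.

Still open, as far as these compounds go, is whether any group at this position can shift the number beyond the scatter. A plain hydrogen on that nitrogen, or a benzyl group carrying a carboxylic acid, would test this.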